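Flavone sigma ligands: swapping the amine on a hexyl chain

A few compounds are considered here, and "the series" means these few. Any claim that something is new, unique, unknown or untested is made for them only; others in the source may bear on it.

This account concerns compound 1, `CN(C)CCCCCCOc1ccc2oc(-c3ccccc3)cc(=O)c2c1`, and the flavone derivatives that share its core. In an assay on isolated protein (Cavia porcellus) with Sigma non-opioid intracellular receptor 1 (Homo sapiens) as the target, read by radioligand binding (a lower number here means a stronger inhibitor, a higher number a weaker inhibitor), compound 1 gives 335 nM. Among the three compounds that have been measured it holds the second highest number: compound 2, `CN(C)CCCCCCCCOc1ccc2oc(-c3ccccc3)cc(=O)c2c1`, gives 143 nM, and compound 3, `O=c1cc(-c2ccccc2)oc2ccc(OCCCCCCN3CCNCC3c3ncccn3)cc12`, gives 14200 nM. The step of a 2.3-fold lower number from compound 1 to compound 2 (0.37 log units; beyond the scatter) is modest, whereas the step of a 42-fold higher number from compound 1 to compound 3 (1.63 log units; beyond the scatter) and the step of a 99-fold higher number from compound 2 to compound 3 (2.00 log units; beyond the scatter) are both large and both run toward weaker inhibition.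

Compound 4, `CCOC(=O)C1CCN(CCCCCCOc2ccc3oc(-c4ccccc4)cc(=O)c3c2)CC1`, has not yet been measured in this assay. It differs from compound 1 in one place: 4-(ethoxycarbonyl)piperidin-1-yl in place of dimethylamino on a saturated chain carbon, six bonds along the chain from an oxygen on an aromatic ring. Among the measured compounds shown here, the only measured step that bears on this change is the one in which the dimethylamino group of compound 1 was also replaced by a six-membered nitrogen ring, a 42-fold higher number from compound 1 to compound 3 (1.63 log units; beyond the scatter). For the measured compounds named here, the ring that enters in compound 4 carries no second basic nitrogen and no aromatic substituent, so the account does not assume a loss of that magnitude, yet it offers no measured step pointing to a gain. The expected step is therefore a 2.7-fold higher number from compound 1 to compound 4 (0.43 log units; beyond the scatter), toward a higher number. For compound 4 the estimate in this assay is 900 nM, with a range from 200 nM to 4000 nM.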

Compound 4, half-maximal inhibitory concentration: 102 nM
Compound 4: the middle estimate sits 8.8-fold (0.95 log units) above what was measured; the whole stated range lies above it.
By their numbers in this assay, from the lowest: compounds 4 and 2 (each within the scatter of the next); then compound 1; then compound 3.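

Among the compounds shown here, compound 4 shows that a six-membered nitrogen ring at this place, on a saturated chain carbon, six bonds along the chain from an oxygen on an aromatic ring, need not weaken the result in this assay: 4-(ethoxycarbonyl)piperidin-1-yl in place of dimethylamino gives a lower number (a 3.3-fold lower number from compound 1 to compound 4 (0.52 log units; beyond the scatter)), opposite in direction to the only earlier ring step. The large loss seen with 2-(pyrimidin-2-yl)piperazin-1-yl is therefore not shared by every ring at this place, as the change between the two ring groups makes plain (a 140-fold lower number from compound 3 to compound 4 (2.14 log units; beyond the scatter)). The remaining comparison (a 1.4-fold lower number from compound 2 to compound 4 (0.15 log units; within the scatter)) puts compound 4 level with compound 2, so the two cannot be told apart in this measurement. Nothing shown here gives a cause for these differences.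

The compounds shown leave open whether the ring or its ester accounts for the result, which an unsubstituted piperidine ring or a carboxylic acid in place of the ethyl ester would help to separate. They also leave open how 4-(ethoxycarbonyl)piperidin-1-yl would behave on a longer chain.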